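Chloro for hydrogen on the phenyl of compound 1

A few compounds are considered here, and "the series" means these few. Any claim that something is new, unique, unknown or untested is made for them only; others in the source may bear on it.

Measured compounds:
- compound 1, `COc1cc(/C=C/C(=O)c2cccc(-n3cc(-c4ccccc4)[nH]c3=O)c2)ccc1O`, 2290 nM
- compound 2, `COc1cc(/C=C/C(=O)c2cccc(-n3cc(-c4ccccc4)[nH]c3=O)c2)cc(OC)c1OC`, 1230 nM
- compound 3, `COc1ccc(-c2cn(-c3cccc(C(=O)/C=C/c4cc(OC)c(OC)c(OC)c4)c3)c(=O)[nH]2)cc1`, 1780 nM

Compound 1, `COc1cc(/C=C/C(=O)c2cccc(-n3cc(-c4ccccc4)[nH]c3=O)c2)ccc1O`, in a functional assay on OVCAR-3 cells (Homo sapiens) for inhibition (a higher number here means a weaker inhibitor of growth, a lower number a stronger inhibitor of growth), gives 2290 nM. This is the highest of the three numbers, but the gaps to compound 3 and to compound 2 both lie within the scatter, so the three compounds cannot be told apart in this assay.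

The new compound 4, `COc1cc(/C=C/C(=O)c2cccc(-n3cc(-c4ccc(Cl)cc4)[nH]c3=O)c2)ccc1O`, differs from compound 1 in one place: chloro in place of hydrogen on an aromatic carbon.

Among the measured compounds shown here, only one measured step exists, and it does not touch the chloro question. From compound 2 to compound 3, a 1.4-fold higher number from compound 2 to compound 3 (0.16 log units; within the scatter), a methoxy took the place of a hydrogen on the same phenyl, and the number stayed within the scatter. For the measured compounds named here, no measured step shows what a chloro at that place does. Given that the single substitution seen on this phenyl left the number unchanged within the scatter, compound 4 is expected to stay close to compound 1 as well; the step from compound 1 to compound 4 is estimated as a 1.1-fold lower number from compound 1 to compound 4 (0.06 log units; within the scatter), no direction beyond the scatter. Compound 4 is therefore estimated at 2000 nM, with a range from 800 nM to 5000 nM.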

Compound 4, concentration for 50% growth inhibition: 1560 nM
Compound 4: middle estimate off by 1.3-fold (0.11 log units), on the high side; the measured number falls inside the stated range.
By their numbers in this assay, from the lowest: compounds 2, 4, 3 and 1 (each within the scatter of the next).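

In this assay, among the compounds shown here, phenyl to 4-chlorophenyl on the core of compound 1 gives the first reading of a chloro at this place (a 1.5-fold lower number from compound 1 to compound 4 (0.17 log units; within the scatter)), so a halogen on this aromatic carbon, para to a large group, is tolerated without a change that can be told from the scatter. For the compounds shown here, the only other step at this place is methoxy in place of hydrogen, on the core of compound 2 (a 1.4-fold higher number from compound 2 to compound 3 (0.16 log units; within the scatter)), so two different groups on two different cores have now left the number within the scatter, and the opposite directions printed for these steps carry no weight. No measurement available here gives a reason for either step, and the series offers no information beyond the numbers themselves.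

Going by these compounds, whether any group at this place can move the number beyond the scatter remains open, for example an amine, a carboxylic acid or a longer alkyl chain in place of the chloro. Also open, on these data alone, is whether the chloro reads the same on the core of compound 2, since the step is known only on the core of compound 1.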